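Working notes: chain-carbon exchange from compound 1 to compound 3

The source may report more compounds than this note shows. Statements on the series, on what has been measured and on what is new or still open speak of the compounds shown alone.

Measured so far, in an assay on CHO cells for displacement of a labelled ligand from prostaglandin E2 receptor EP3 subtype (Homo sapiens), read by radioligand binding; on this read-out lower numbers stand for stronger inhibition and higher numbers for weaker inhibition:
compound 1 `CC(C)C(Cc1nnc[nH]1)c1ccc(-c2ccc3cccc(F)c3c2)[nH]c1=O` gives 10 nM
compound 2 `CCn1ncc2c(C)cc(-c3ccc([C@@]4(C)CCNC4=O)c(=O)[nH]3)cc21` gives 5 nM

Compound 1 holds the higher of the two numbers measured in this assay. Its nearest neighbour is compound 2, whose number lies within the usual scatter of this assay, so the two are not distinguished and no order between them is claimed. The two compounds share the core but differ in several places at once, so no single-point step can be read from them.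

Compound 3 `CC(C)C(Nc1nccs1)c1ccc(-c2ccc3cccc(F)c3c2)[nH]c1=O` is the next candidate. It differs from compound 1 in one place: (1,3-thiazol-2-yl)amino in place of (4H-1,2,4-triazol-3-yl)methyl on a saturated chain carbon bound to an aromatic carbon and a saturated chain carbon. Within the data shown here, no measured pair shows this exchange, so the expectation rests on the size of the change alone. The group that leaves and the group that enters are of the same heavy-atom count, each with one hydrogen-bond donor and a five-membered aromatic ring, which argues for a small step. The step from compound 1 to compound 3 is expected to be a 1.5-fold higher number from compound 1 to compound 3 (0.18 log units; within the scatter), not beyond the scatter in either direction. Compound 3 is therefore estimated at 15 nM, with a range from 4 nM to 60 nM.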

Compound 3, inhibition constant: 9.4 nM
Estimate against measurement, compound 3: 1.6-fold (0.20 log units) above, within the range that was stated.
By their numbers in this assay, from the lowest: compounds 2, 3 and 1 (each within the scatter of the next).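

In this assay, (1,3-thiazol-2-yl)amino in place of (4H-1,2,4-triazol-3-yl)methyl on a saturated chain carbon bound to an aromatic carbon and a saturated chain carbon gives a 1.1-fold lower number from compound 1 to compound 3 (0.03 log units; within the scatter). Among these compounds, this is the first step that can be read at a single place, and it shows that this exchange, which alters both the five-membered aromatic ring and the group joining it to the chain carbon, does not move the number beyond the scatter. No measurement shown here bears on the reason for this result.

Both groups shown at this position have the same heavy-atom count and a five-membered aromatic ring, so the response to a carboxylic acid, an amine or a longer chain there remains open. As far as these compounds go, whether the same exchange behaves alike on the core of compound 2 also remains open.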